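The compounds below may be only part of what the source reports. "The series", "measured", "known", "first", "only" and "open" are said of these compounds alone.

Compound 1 `C[C@@H](Cn1ccc(-c2ccc(C#N)c(Cl)c2)n1)NC(=O)c1ccccc1`: 1830 nM
Compound 2 `Cc1ccnc(N[C@@H](C)Cn2ccc(-c3ccc(C#N)c(Cl)c3)n2)n1`: 1330 nM

Among the measured compounds shown here, in a functional assay on LNCaP cells (Homo sapiens) for antiproliferative activity, read by CCK-8 assay, with a stated time of 6 days (a higher number here means a weaker inhibitor, a lower number a stronger inhibitor), compound 2 holds the lowest of the two numbers, yet the single measured step, a 1.4-fold lower number from compound 1 to compound 2 (0.14 log units; within the scatter), stays within the scatter, so the two compounds cannot be ranked. That step swaps the entire group on the amine nitrogen and says nothing about a small change on the pyrimidine. Compound 3 `C[C@@H](Cn1ccc(-c2ccc(C#N)c(Cl)c2)n1)Nc1nccc(Cl)n1` differs from compound 2 by chloro in place of methyl on an aromatic carbon. For the measured compounds named here, no measured step bears on this exchange, so the expected change, a 1.0-fold lower number from compound 2 to compound 3 (0.01 log units; within the scatter), is none beyond the scatter. Compound 3 is therefore estimated at 1300 nM, with a range from 500 nM to 3500 nM.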

Compound 3, half-maximal inhibitory concentration: 1400 nM
Compound 3: the middle estimate sits 1.1-fold (0.03 log units) below what was measured; measured number inside the range.
By their numbers in this assay, from the lowest: compounds 2, 3 and 1 (each within the scatter of the next).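

In this assay, among the compounds shown here, the first small change on the pyrimidine, which puts chloro where methyl stood on one carbon, gives a 1.1-fold higher number from compound 2 to compound 3 (0.02 log units; within the scatter), so the two groups cannot be told apart here. With chloro in place, 4-chloropyrimidin-2-yl against benzoyl on the amine nitrogen gives a 1.3-fold lower number from compound 1 to compound 3 (0.12 log units; within the scatter), so this pair cannot be ranked either. Nothing available explains why these numbers stay so close. Still open, as far as these compounds go, is whether a different group at this carbon, such as an amine, a methoxy group or a carboxylic acid, would move the number beyond the scatter.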